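Swapping a bicyclic amine for diethylamino on the side chain

The compounds below may be only part of what the source reports. "The series", "measured", "known", "first", "only" and "open" are said of these compounds alone.

Compound 1 `COc1cc2c(Oc3ccc(NC(=O)NN4C(=O)CSC4c4c(F)cccc4F)c(Cl)c3)ccnc2cc1OCCCN1CCCC1` is recorded in a functional assay on MDA-MB-231 cells (Homo sapiens) for antiproliferative activity, read by MTT assay, with a stated time of 72 h (a higher number here means a weaker inhibitor, a lower number a stronger inhibitor), as "not determined" (no result reported), and compound 3 `COc1cc2c(Oc3c(F)cc(NC(=O)NN4C(=O)CSC4c4c(F)cccc4F)cc3F)ccnc2cc1OCCCN1CCc2sccc2C1`, which shares its core, is recorded in this assay as "not determined" (no result reported). Going by the values given here, the only measured member of the set, compound 2 `COc1cc2c(Oc3c(F)cc(NC(=S)NN4C(=O)CSC4c4c(F)cccc4F)cc3F)ccnc2cc1OCCCN1CCCC1`, gives 8120 nM in this assay. Compound 3 therefore stands without a value, and nothing measured links it to any other compound. Compound 4 `CCN(CC)CCCOc1cc2nccc(Oc3c(F)cc(NC(=O)NN4C(=O)CSC4c4c(F)cccc4F)cc3F)c2cc1OC` differs from compound 3 by a group of 5 heavy atoms (4 carbon, 1 nitrogen; no ring) in place of a group of 9 heavy atoms (7 carbon, 1 nitrogen, 1 sulfur; one five-membered aromatic ring with 1 hetero atom, one six-membered non-aromatic ring with 1 hetero atom), on a saturated chain carbon, three bonds along the chain from an oxygen on an aromatic ring. With no measured step of this kind in the data, no direction can be claimed, and any shift beyond the scatter is uncertain. Among the compounds with values here, on the single measured value for compound 2, compound 4 is expected to give about 5000 nM in this assay, within a range of 1000 nM to 25000 nM.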

Compound 4, half-maximal inhibitory concentration: 3790 nM
Compound 4: the middle estimate sits 1.3-fold (0.12 log units) above what was measured; measured number inside the range.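

Going by these compounds alone, compound 3 has no single value, so the change to diethylamino in compound 4 gives no step that can be read. The compounds shown leave open whether exchanging this side-chain amine shifts activity at all. Nothing available bears on a cause for the result.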